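This account rests on a few compounds, and the source may have more. Where it says the series, first, only, none or still open, it means among the compounds named here.

Compound 1 `O=C(/C=C/c1ccc2c(c1)C(=O)N(Cc1ccc(-c3ccccc3)cc1)C2)NO` gives 98 nM in an assay on isolated protein for inhibition of histone deacetylase 4 (Homo sapiens); a lower number here means a stronger inhibitor, a higher number a weaker inhibitor.
Compound 2 `O=C(/C=C/c1ccc2c(c1)C(=O)N(Cc1ccc(-c3cccnc3)cc1)C2)NO` gives 56 nM in this assay.
Compound 3 `O=C(/C=C/c1ccc2c(c1)C(=O)N(Cc1ccc(-c3ccncc3)cc1)C2)NO` gives 2100 nM in this assay.

Compound 3 stands at the highest number of the three, that is, as the weakest inhibitor: the gaps are a 21-fold higher number from compound 1 to compound 3 (1.33 log units; beyond the scatter) and a 38-fold higher number from compound 2 to compound 3 (1.57 log units; beyond the scatter), both beyond the scatter. Compound 1 and compound 2 differ only by a 1.8-fold lower number from compound 1 to compound 2 (0.24 log units; within the scatter), which is within the scatter.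

Compound 4 `CC(C)(C)c1ccc(CN2Cc3ccc(/C=C/C(=O)NO)cc3C2=O)cc1` differs from compound 3 in one place: tert-butyl in place of pyridin-4-yl on an aromatic carbon. Within the data shown here, the steps that bear on this change are those that brought the pyridin-4-yl in, a 21-fold higher number from compound 1 to compound 3 (1.33 log units; beyond the scatter) and a 38-fold higher number from compound 2 to compound 3 (1.57 log units; beyond the scatter), both large. Among the measured compounds shown here, no measured compound carries a tert-butyl, so how it compares with phenyl is unknown. Because the weak result of compound 3 is 2100 nM and the removal of the pyridin-4-yl undoes the change that produced it, compound 4 is expected to return toward the level of compound 1. The expected step is a 14-fold lower number from compound 3 to compound 4 (1.15 log units; beyond the scatter), a large fall in the number. For compound 4 the estimated value is 150 nM, with a range from 40 nM to 600 nM.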

Compound 4, half-maximal inhibitory concentration: 180 nM
Compound 4: the middle estimate sits 1.2-fold (0.08 log units) below what was measured; low and high end bracket the measured number.
By their numbers in this assay, from the lowest: compounds 2, 1 and 4 (each within the scatter of the next, the first and the last beyond it); then compound 3.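

Replacing pyridin-4-yl with tert-butyl gives a 12-fold lower number from compound 3 to compound 4 (1.07 log units; beyond the scatter) in this assay, so a group with no ring can also sit at this position without the large loss seen with pyridin-4-yl. Phenyl and tert-butyl cannot be told apart here, given a 1.8-fold higher number from compound 1 to compound 4 (0.26 log units; within the scatter), so among these compounds an aromatic ring at this position is not required. Pyridin-3-yl and tert-butyl can be told apart, by a 3.2-fold higher number from compound 2 to compound 4 (0.51 log units; beyond the scatter), a modest step that leaves compound 3 as the only one of the four with a large loss.

Nothing available explains why pyridin-4-yl alone stands apart from the other three groups. From the compounds shown here alone, how a small methyl, an amine or a carboxylic acid would behave at this position remains open.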